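Solubility notes on a shared core with varied aryl amines

The source may report more compounds than this note shows. Statements on the series, on what has been measured and on what is new or still open speak of the compounds shown alone.

Measured compounds:
Compound 1, `CNC(=O)c1cc(Oc2ccc3nc(Nc4ccccc4)ncc3c2)ccn1`: in a physicochemical assay for solubility, at pH 7 (on this read-out higher numbers stand for higher solubility and lower numbers for lower solubility), compound 1 gives < 1000 nM, which is a limit of the assay and not a number.
Compound 2, `CNC(=O)c1cc(Oc2ccc3nc(Nc4cccc(Cl)c4)ncc3c2)ccn1`: in this assay compound 2 gives < 1000 nM, again a limit.
Compound 3, `CNC(=O)c1cc(Oc2ccc3nc(Nc4cccc(Br)c4)ncc3c2)ccn1`: in this assay compound 3 gives < 1000 nM, also a limit.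

Compound 2 therefore stands only at a limit, and the two further values shown are limits as well, all sitting at the limit of < 1000 nM in this assay, at which 3 of the 3 values shown sit. The change to compound 4 `CNC(=O)c1cc(Oc2ccc3nc(Nc4ccc(C(C)C)cc4)ncc3c2)ccn1` is 4-isopropylphenyl in place of 3-chlorophenyl on a nitrogen on an aromatic ring. Of the measured steps, a step that the two limits leave unreadable from compound 1 to compound 2, a step that the two limits leave unreadable from compound 1 to compound 3 and a step that the two limits leave unreadable from compound 2 to compound 3 are all unreadable, and none of them introduces an isopropyl group; they bear on the present change only in showing that every member so far rests at the limit. No readable step is expected, and the most likely outcome is a further limit. The estimate for compound 4 in this assay is 400 nM, within 80 nM to 2000 nM. The step from compound 2 to compound 4 is expected to be a step that the limit leaves unreadable from compound 2 to compound 4, unlikely to be readable.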

Compound 4, solubility: < 1000 nM
Compound 4 ended at the assay's limit; the forecaster's own chance of this, stated with the estimate: 75%; the middle value is on the limit's open side.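

In this assay compound 4 gives < 1000 nM, a limit of the assay and not a number, so its steps from compound 1, compound 2 and compound 3 cannot be read. The compounds shown leave open how these four compare in solubility, and whether any aryl amine on the shared core gives a readable value.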